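The source may hold more compounds than are shown below. What is called first, only, known or untested is meant among the compounds shown, and "the series" means these compounds.

Among the compounds with values here, in an ADME assay on WI-38 cells (Homo sapiens) for cytotoxicity, read by MTT assay, with a stated time of 72 h (on this read-out lower numbers stand for stronger inhibition and higher numbers for weaker inhibition), compound 1 `O=C(CCc1cccc2c1B(O)OC2)Nc1ccccc1` gives 30000 nM, the only actual number so far. Compound 2 `O=C(CCc1cccc2c1B(O)OC2)Nc1nccs1` sits at a limit of the assay, > 100000 nM. Compound 3 `C#Cc1ccc(NC(=O)CCc2cccc3c2B(O)OC3)cc1` sits at a limit as well, > 100000 nM. Compound 4 `C#Cc1ccccc1NC(=O)CCc1cccc2c1B(O)OC2` is unmeasured and differs from compound 1 by ethynyl in place of hydrogen on an aromatic carbon, with ethynyl in place of hydrogen on an aromatic carbon, ortho to a large group.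

The nearest guide is an at least 3.3-fold higher number from compound 1 to compound 3 (0.52 log units; beyond the scatter), which is the same kind of exchange. The thiazolyl exchange, an at least 3.3-fold higher number from compound 1 to compound 2 (0.52 log units; beyond the scatter), bears on it less directly. Both steps end at the limit of > 100000 nM in this assay, at which 2 of the 3 values shown sit, so only their minimum size is known.

A modest rise in this assay is expected, with an estimated step of a 2.3-fold higher number from compound 1 to compound 4 (0.37 log units; beyond the scatter). For compound 4 the expected value is 70000 nM, with an estimated range of 25000 nM to 170000 nM.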

Compound 4, half-maximal inhibitory concentration: 18000 nM
The estimate for compound 4 lay 3.9-fold (0.59 log units) above the measured number; the measured number lies below the stated range.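

In this assay, ethynyl in place of hydrogen ortho to a large group gives a 1.7-fold lower number from compound 1 to compound 4 (0.22 log units; within the scatter), so at this position the exchange leaves no change beyond the scatter. The same kind of exchange in compound 3 gives an at least 3.3-fold higher number from compound 1 to compound 3 (0.52 log units; beyond the scatter), so ethynyl does not have a single outcome across these two places. Only a minimum is known for that second step: the limit of > 100000 nM in this assay, at which 2 of the 4 values shown sit.

Going by these compounds, whether an amine or a carboxylic acid at the position used in compound 4 would also stay within the scatter of compound 1 remains open. So does the true size of the step to compound 3.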